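Compound 2 to compound 3: sulfonyl for carbamate

The source may report more compounds than this note shows. Statements on the series, on what has been measured and on what is new or still open speak of the compounds shown alone.

compound 1 `Cn1cc(/C=C2\CCC=CC2=O)c2ccccc21` gives 3370 nM
compound 2 `COc1cc(/C=C2\CN(C(=O)OCc3ccccc3)C=CC2=O)cc(OC)c1OC` gives 24200 nM

In a functional assay on MDA-MB-231 cells (Homo sapiens) for antiproliferative activity, read by sulforhodamine B assay, with a stated time of 72 h (on this read-out lower numbers stand for stronger inhibition and higher numbers for weaker inhibition), compound 2 holds the higher of the two numbers at 24200 nM, and compound 1 lies lower at 3370 nM, a gap beyond the scatter. Compound 3 `COc1cc(/C=C2\CN(S(=O)(=O)c3ccc(C)cc3)C=CC2=O)cc(OC)c1OC` departs from compound 2 by a single change: (4-methylphenyl)sulfonyl in place of benzyloxycarbonyl on an amine nitrogen in a ring. In words, (4-methylphenyl)sulfonyl stands in place of benzyloxycarbonyl on an amine nitrogen in a ring. Within the data shown here, no measured pair isolates this change, so the expectation is weakly grounded. A moderate fall in the number is expected, an estimated step of a 2.4-fold lower number from compound 2 to compound 3 (0.38 log units; beyond the scatter). The estimate for compound 3 is 10000 nM, with an expected range of 2500 nM to 35000 nM.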

Compound 3, half-maximal inhibitory concentration: 22200 nM
Compound 3: the middle estimate sits 2.2-fold (0.35 log units) below what was measured; measured number inside the range.
By their numbers in this assay, from the lowest: compound 1; then compounds 3 and 2 (each within the scatter of the next).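

In this assay the exchange of benzyloxycarbonyl for (4-methylphenyl)sulfonyl on an amine nitrogen in a ring gives a 1.1-fold lower number from compound 2 to compound 3 (0.04 log units; within the scatter) and so does not separate the two groups at this position. Both groups carry one six-membered aromatic ring of carbon only, so this read-out tolerates the sulfonyl in place of the carbamate carbonyl here. No measured property is available to account for this result. Still open, on these data alone, is whether a plain acetyl group, a simple methyl or a chain ending in an amine on this nitrogen would separate from these two. Compound 1 differs from compound 2 and compound 3 in more than one place, so its lower number cannot be assigned to any single change.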